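The source may report more compounds than this note shows. Statements on the series, on what has been measured and on what is new or still open speak of the compounds shown alone.

Compound 1 `CCCCCCCn1cc(COC[C@@H]2OC[C@H](N)[C@@H]2O)nn1` carries a heptyl chain on the aromatic nitrogen of the shared core. In a functional assay on MGC-803 cells (Homo sapiens) for antiproliferative activity, read by MTT assay, with a stated time of 48 h (a higher number here means a weaker inhibitor, a lower number a stronger inhibitor), compound 1 reaches only > 128000 nM, which is a limit of the assay and not a number (the limit of > 128000 nM in this assay, at which 1 of the 3 values shown sits). Compound 2 `CCCCCCCCCn1cc(COC[C@@H]2OC[C@H](N)[C@@H]2O)nn1` differs from compound 1 by ethyl in place of hydrogen on a saturated chain carbon, seven bonds along the chain from an aromatic nitrogen. In this assay compound 2 gives 13800 nM, so the step of an at least 9.2-fold lower number from compound 1 to compound 2 (0.96 log units; beyond the scatter). Compound 3 `CCCCCCCCCCCCCCn1cc(COC[C@@H]2OC[C@H](N)[C@H]2O)nn1` has a longer chain, and the difference between its core and that of compound 1 is not broken down here. In this assay, going by the values given here, compound 3 gives 8790 nM, a value within the scatter of the one for compound 2. Compound 4 `CCCCCCCCCCCCCCCCn1cc(COC[C@@H]2OC[C@H](N)[C@H]2O)nn1` is not yet measured; it differs from compound 3 by ethyl in place of hydrogen on a saturated chain carbon, ten or more bonds along the chain from an aromatic nitrogen. This is the same kind of change as that from compound 1 to compound 2, but at a different place on the chain, as the two differences just given state. The values of compound 2 and compound 3 lie within the scatter of each other, so a further lengthening is expected to give a small step, a 1.3-fold lower number from compound 3 to compound 4 (0.10 log units; within the scatter), far smaller than the earlier one. For compound 4 in this assay the estimate is 7000 nM, between 3000 nM and 16000 nM.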

Compound 4, half-maximal inhibitory concentration: 5340 nM
Estimate against measurement, compound 4: 1.3-fold (0.12 log units) above; measured number inside the range.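

In this assay, ethyl in place of hydrogen on a saturated chain carbon gives a 1.6-fold lower number from compound 3 to compound 4 (0.22 log units; within the scatter), and this step does not match the one seen with the same change on the core of compound 1: the same change on two cores in this assay, an at least 9.2-fold lower number (0.96 log units; beyond the scatter) from compound 1 to compound 2 and a 1.6-fold lower number (0.22 log units; within the scatter) from compound 3 to compound 4, at least 5.6-fold (0.75 log units) apart, beyond the scatter of two such steps. Compound 1 gives a limit of the assay and not a number: the limit of > 128000 nM in this assay, at which 1 of the 4 values shown sits. The change therefore does not carry over with one size from the core of compound 1 to the core of compound 3, but the two pairs differ both in core and in the place of the change on the chain, so the data do not show which of these goes with the gap.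

The compounds shown leave open how a heptyl or a nonyl chain would read on the core of compound 3, which would set the core apart from the place on the chain. They also leave open what a longer chain than that of compound 4 would give, or a carboxylic acid at the chain end.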